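An Amino Group Added to the Ring of Compound 1

The source may report more compounds than this note shows. Statements on the series, on what has been measured and on what is new or still open speak of the compounds shown alone.

Measured compounds:
- compound 1, `O=C(Nc1ccccn1)c1cc2n(n1)CCCC2`: 364 nM
- compound 2, `COc1cccnc1NC(=O)c1cc2n(n1)CCCC2`: "not active" (no number reported)

Two compounds share a core and an amide linker and differ only in what sits on the six-membered ring. Among the measured compounds shown here, in a functional assay on HEK293 cells for negative allosteric modulation of metabotropic glutamate receptor 5 (Rattus norvegicus), read by FLIPR and calcium flux, with a stated time of 170 s (a higher number here means a weaker inhibitor, a lower number a stronger inhibitor), compound 1 gives 364 nM, the only number reported here. For the measured compounds named here, compound 2, which carries a methoxy group on that ring, is reported in this assay as "not active" (no number reported), so no number stands beside it and no step between the two can be sized. Compound 1 therefore stands as the single anchor for everything that follows.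

Compound 3, `Nc1ccc(NC(=O)c2cc3n(n2)CCCC3)nc1`, has not yet been measured in this assay. It differs from compound 1 by a single change: amino in place of hydrogen on an aromatic carbon. The amino group brings one hydrogen-bond donor and one acceptor to the ring. The result for compound 2 shows that a substituent on this ring can remove activity, but that compound carries a different group at a different place, so it cannot be read as a step.

Going by the values given here, with only one number to lean on, the expected step from compound 1 is a 1.6-fold higher number from compound 1 to compound 3 (0.22 log units; within the scatter), a modest weakening that may well fall within the scatter. Compound 3 is estimated at 600 nM, with a range from 150 nM to 2500 nM.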

Compound 3, half-maximal inhibitory concentration: "not active" (no number reported)
For compound 3 the study gives words and no number; no gap can be computed for the estimate.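

In this assay, among the compounds shown here, compound 3 is reported as "not active" with no number, so no step from compound 1 at 364 nM can be sized. Nothing shown here bears on the reason for this result. The compounds shown leave open how large the change with the amino group is, and whether any group on this ring keeps activity.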